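Methyl for Methoxy on a Thiophene-Bearing Nucleoside

This account rests on a few compounds, and the source may have more. Where it says the series, first, only, none or still open, it means among the compounds named here.

Within the data shown here, compound 1 `COc1ncnc2c1c(-c1ccsc1)cn2[C@@H]1O[C@H](CO)[C@@H](O)[C@H]1O` is the only compound with a number in a functional assay on HCT-116 cells (Homo sapiens), read by MTT assay, with a stated time of 72 h; a higher number here means a weaker inhibitor, a lower number a stronger inhibitor; in this assay compound 1 gives 120 nM. Compound 2 `COc1ncnc2c1c(-c1ccccc1)cn2[C@@H]1O[C@H](CO)[C@@H](O)[C@H]1O` reaches only a limit of the assay, and in this assay compound 2 gives > 20000 nM. Among the measured compounds shown here, the single measured step, an at least 160-fold higher number from compound 1 to compound 2 (2.22 log units; beyond the scatter), rests on the limit of > 20000 nM in this assay, at which 1 of the 2 values shown sits, and concerns the thiophen-3-yl, which compound 3 keeps unchanged.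

Compound 3 `Cc1ncnc2c1c(-c1ccsc1)cn2[C@@H]1O[C@H](CO)[C@@H](O)[C@H]1O` differs from compound 1 by methyl in place of methoxy on an aromatic carbon. For the measured compounds named here, no measured step touches the methoxy, so the one comparison available says nothing directly about this change, and only its size gives a sense of how sensitive this assay can be to a single replacement on the shared core. The change at hand is the smaller one in atoms. A step that may stay within the scatter, or drift towards a higher number, is expected for this assay.

Compound 3 is therefore expected to give 220 nM in this assay, within a range from 40 nM to 1500 nM, which amounts to an expected step of a 1.8-fold higher number from compound 1 to compound 3 (0.26 log units; within the scatter).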

Compound 3, half-maximal inhibitory concentration: 460 nM
The estimate for compound 3 lay 2.1-fold (0.32 log units) below the measured number, and the stated range covers the measured number.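

Compound 3 shows that the methoxy of compound 1 is not needed for a measurable number at this position, yet the position is not indifferent to the change: in this assay, methyl in place of methoxy gives a 3.8-fold higher number from compound 1 to compound 3 (0.58 log units; beyond the scatter), a modest step that ends on a real value rather than at a limit. Among these compounds, this is the first comparison at this position, and it is also the first in the set with a number on both sides, whereas the step at the thiophen-3-yl, an at least 160-fold higher number from compound 1 to compound 2 (2.22 log units; beyond the scatter), gives only a minimum size, and the value behind it is a limit: the limit of > 20000 nM in this assay, at which 1 of the 3 values shown sits. Nothing shown here accounts for why the number rises on going from methoxy to methyl.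

With only methoxy and methyl shown at this position, it remains open how an amine, a chlorine or a longer chain such as ethoxy would read in this assay. Going by these compounds, it also remains open whether the same step would appear with a group other than thiophen-3-yl on the shared core.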